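A pyrazole group in place of a methyl

The source may hold more compounds than are shown below. What is called first, only, known or untested is meant among the compounds shown, and "the series" means these compounds.

Measured so far in an ADME assay on BaF3 cells (Mus musculus) for antiproliferative activity, read by CCK-8 assay, with a stated time of 72 h; a higher number here means a weaker inhibitor of growth, a lower number a stronger inhibitor of growth:
compound 1 `O=C(CCSc1ccc2c(/C=C/c3ccccn3)n[nH]c2c1)Nc1ccc(CN2CCCC2)c(C(F)(F)F)c1` gives 4000 nM
compound 2 `CN1CCN(Cc2ccc(C(=O)NCCCSc3ccc4c(/C=C/c5ccccn5)n[nH]c4c3)cc2C(F)(F)F)CC1` gives 4400 nM
compound 3 `Cc1n[nH]c2cc(SCCC(=O)Nc3ccc(CN4CCN(C)CC4)c(C(F)(F)F)c3)ccc12` gives 3900 nM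

Compound 3 at 3900 nM lies within the scatter of both other compounds, so the three values set no order. Compound 4 `CN1CCN(Cc2ccc(NC(=O)CCSc3ccc4c(-c5cnn(C)c5)n[nH]c4c3)cc2C(F)(F)F)CC1` carries 1-methyl-1H-pyrazol-4-yl in place of the methyl of compound 3 on an aromatic carbon, a change counted as 1-methyl-1H-pyrazol-4-yl in place of methyl on an aromatic carbon and not yet tested. Among the measured compounds shown here, no measured pair differs in one place only. Compound 1 at 4000 nM and compound 2 at 4400 nM hold a larger group on that same carbon and stay within the scatter of compound 3, though they differ elsewhere too. No step beyond the scatter is therefore expected in this assay for this change. The estimated 1.1-fold lower number from compound 3 to compound 4 (0.05 log units; within the scatter) is expected to stay small. Compound 4 is expected near 3500 nM within an estimated range from 1500 nM to 7000 nM for now.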

Compound 4, concentration for 50% growth inhibition: 1400 nM
Compound 4: the middle estimate sits 2.5-fold (0.40 log units) above what was measured; the whole stated range lies above it.
By their numbers in this assay, from the lowest: compound 4; then compounds 3, 1 and 2 (each within the scatter of the next).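

In this assay, among the compounds shown here, 1-methyl-1H-pyrazol-4-yl in place of methyl gives a 2.8-fold lower number from compound 3 to compound 4 (0.44 log units; beyond the scatter) and is the first change beyond the scatter at this aromatic carbon. Because compounds 3 and 4 differ in one place only, the pair shows that the group on this carbon can alone shift the number. No measurement shown accounts for the step. The compounds leave open whether the step depends on the ring nitrogens or on any ring at this carbon, which a phenyl group there would separate. They also leave open whether the methyl on the pyrazole matters.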